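This account rests on a few compounds, and the source may have more. Where it says the series, first, only, none or still open, it means among the compounds named here.

Measured in a functional assay on A2780 cells (Homo sapiens) for antiproliferative activity, read by resazurin assay, with a stated time of 72 h; a higher number here means a weaker inhibitor, a lower number a stronger inhibitor:
- compound 1 `Cc1ccccc1CN(C)C(=O)c1cc2c(Cc3ccccc3)n[nH]c2cc1O`: 4400 nM
- compound 2 `Cc1cccc(CN(C)C(=O)c2cc3c(Cc4ccccc4)n[nH]c3cc2O)c1`: "not determined" (no result reported)
- compound 3 `CN(Cc1ccc(F)cc1)C(=O)c1cc2c(Cc3ccccc3)n[nH]c2cc1O`: 4100 nM

Compound 3 stands level with compound 1, as the measured step is a 1.1-fold lower number from compound 1 to compound 3 (0.03 log units; within the scatter). Compound 4 `CCc1ccc(CN(C)C(=O)c2cc3c(Cc4ccccc4)n[nH]c3cc2O)cc1` is not yet measured. It carries ethyl in place of fluoro on an aromatic carbon, para to a large group: ethyl in place of fluoro on an aromatic carbon. Going by the values given here, only one measured step bears on this change: a 1.1-fold lower number from compound 1 to compound 3 (0.03 log units; within the scatter), with 4-fluorophenyl in place of 2-methylphenyl. Among the compounds with values here, one step is thin evidence, and no measured compound carries ethyl. No shift beyond the scatter is therefore expected in this assay, and the estimated step is a 1.0-fold lower number from compound 3 to compound 4 (0.01 log units; within the scatter). For compound 4 the expected value is 4000 nM, with an estimated range of 1800 nM to 9000 nM.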

Compound 4, half-maximal inhibitory concentration: 9400 nM
Beside the measured number, compound 4's estimate is 2.4-fold (0.37 log units) below it, and the stated range ends below it.
By their numbers in this assay, from the lowest: compounds 3 and 1 (each within the scatter of the next); then compound 4.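

In this assay this aromatic carbon, para to a large group, proves responsive: ethyl in place of fluoro gives (a 2.3-fold higher number from compound 3 to compound 4 (0.36 log units; beyond the scatter)), and 4-ethylphenyl in place of 2-methylphenyl gives (a 2.1-fold higher number from compound 1 to compound 4 (0.33 log units; beyond the scatter)). Going by these compounds alone, both steps are modest, but they are the first beyond the scatter, and they leave compound 4 with the highest number among the compounds with values. No measurement at hand accounts for the shift.

From the compounds shown here alone, whether a propyl group, a hydroxyl or an amine at this carbon would continue or reverse the rise stays open. Steps involving compound 2 cannot be read, as it has no reported result.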